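From a nitrophenyl amide to a pyrazinyl amide

The compounds below may be only part of what the source reports. "The series", "measured", "known", "first", "only" and "open" are said of these compounds alone.

Compound 1: `CCCCNC(=O)c1c(O)c2cccnc2n(-c2ccccc2)c1=O`; in a functional assay on the whole organism for inhibition, with Rattus norvegicus as the target, read by cytopathic effect and paw edema, at a dose of 100 mg/kg by the oral route (on this read-out lower numbers stand for less inhibition and higher numbers for more inhibition at the one dose given (going by the name of the read-out)), compound 1 gives 20.4%.
Compound 2: `CN(C)CCNC(=O)c1c(O)c2cccnc2n(-c2ccccc2)c1=O`; compound 2 gives 18.4%.
Compound 3: `O=C(Nc1ccc([N+](=O)[O-])cc1)c1c(O)c2cccnc2n(-c2ccccc2)c1=O`; compound 3 gives -25.8%.

Compound 3 stands lowest of the three measured values: a number 46.2 percentage points lower from compound 1 to compound 3 (beyond the scatter), and a number 44.2 percentage points lower from compound 2 to compound 3 (beyond the scatter), whereas a number 2 percentage points lower from compound 1 to compound 2 (within the scatter). Compound 4, `O=C(Nc1cnccn1)c1c(O)c2cccnc2n(-c2ccccc2)c1=O`, differs from compound 3 in one place: pyrazin-2-yl in place of 4-nitrophenyl on an amide-type nitrogen.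

Going by the values given here, the steps that bear on this change are the two that placed 4-nitrophenyl on the amide-type nitrogen in place of butyl or 2-(dimethylamino)ethyl; both were large falls, of roughly the same size. Among the compounds with values here, no measured step carries pyrazin-2-yl, so the move from compound 3 to compound 4 has no direct precedent, and the only firm point is that the single aryl amide measured lies far below both alkyl amides. An expectation for compound 4 therefore rests on it remaining an aryl amide, kept nearer to compound 3 than to compounds 1 and 2, with a step of a number 20.8 percentage points higher from compound 3 to compound 4 (beyond the scatter) estimated to be upward but uncertain. Compound 4 is estimated at -5%, in a range from -30% to 22%.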

Compound 4, a percentage reported as inhibition, in the whole organism at one dose (the size of the read-out at that dose, not a potency): 21.2%
Compound 4: the middle estimate sits 26.2 percentage points below what was measured; the measured number falls inside the stated range.
By their numbers in this assay, from the lowest: compound 3; then compounds 2, 1 and 4 (each within the scatter of the next).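

In this assay, the step of a number 47 percentage points higher from compound 3 to compound 4 (beyond the scatter) shows that the low number of compound 3 does not hold for every six-membered aromatic ring on the amide-type nitrogen, since compound 4 keeps such a ring and loses the fall. The earlier compounds shown here left open whether an aryl amide at this position would always lie far below the alkyl amides, but the steps of a number 2.8 percentage points higher from compound 2 to compound 4 (within the scatter) and a number 0.8 percentage points higher from compound 1 to compound 4 (within the scatter) place compound 4 level with both, so among the four compounds only compound 3, with 4-nitrophenyl, stands apart. No measurement on hand explains why 4-nitrophenyl and pyrazin-2-yl differ so widely here.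

This single change removes the nitro group and also puts nitrogen into the ring, so the two cannot be told apart; phenyl, 4-aminophenyl or pyridin-2-yl on the same amide-type nitrogen would begin to separate them. On these data alone, it also remains open whether any group at this position, such as a longer alkyl chain or a carboxylic acid on the chain, would lift the number clear of compounds 1, 2 and 4.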